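From isopropoxy to cyclopentyloxy in a cell assay

A few compounds are considered here, and "the series" means these few. Any claim that something is new, unique, unknown or untested is made for them only; others in the source may bear on it.

Compound 1 `O=C(Nc1cc(Cl)nc(Cl)c1)Nc1cc(Cl)nc(Cl)c1` gives 180 nM
Compound 2 `CC(C)Oc1cc(NC(=O)Nc2cc(Cl)nc(Cl)c2)cc(Cl)n1` gives 5230 nM

Among the measured compounds shown here, in a functional assay on HCT-116 cells (Homo sapiens) for inhibition, read by MTT assay, with a stated time of 72 h, in the presence of a further agent that is not named here (a higher number here means that more compound is needed for the effect, a lower number that less compound is needed), compound 2 stands at 5230 nM and holds the higher number of the two, the one measured step being a 29-fold higher number from compound 1 to compound 2 (1.46 log units; beyond the scatter) for isopropoxy in place of chloro on an aromatic carbon. Compound 3 `O=C(Nc1cc(Cl)nc(Cl)c1)Nc1cc(Cl)nc(OC2CCCC2)c1` differs from compound 2 as cyclopentyl in place of isopropyl on an oxygen on an aromatic ring and so carries cyclopentyl in place of isopropyl on an oxygen on an aromatic ring. For the measured compounds named here, that large step replaced chloro, so it bears only indirectly, and no measured step changes the group on this oxygen. The expected step is a 1.2-fold lower number from compound 2 to compound 3 (0.07 log units; within the scatter) and no shift beyond the scatter is expected. Compound 3 is estimated at 4500 nM with 1500 nM to 15000 nM as its expected range.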

Compound 3, half-maximal effective concentration: 5120 nM
Estimate against measurement, compound 3: 1.1-fold (0.06 log units) below, and the stated range covers the measured number.
By their numbers in this assay, from the lowest: compound 1; then compounds 3 and 2 (each within the scatter of the next).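

In this assay, going from isopropyl to cyclopentyl on this oxygen adds a five-membered ring of carbon only, yet the step is a 1.0-fold lower number from compound 2 to compound 3 (0.01 log units; within the scatter) and so does not separate the two groups. Cyclopentyloxy in place of chloro gives a 28-fold higher number from compound 1 to compound 3 (1.45 log units; beyond the scatter) and stays far from compound 1, so among these compounds the large rise goes with the loss of chloro and not with which of these two ethers enters. Nothing at hand explains either step.

On these data alone, what an amine or a methoxy group in place of chloro on this aromatic carbon would give remains open. So does the outcome of a longer chain on the oxygen.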